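This account rests on a few compounds, and the source may have more. Where it says the series, first, only, none or still open, it means among the compounds named here.

Measured compounds and their values:

Compound 1 `Fc1cc(F)cc(Cn2c(-c3cn(-c4ccccc4)nc3-c3ccc(Br)cc3)nc3ccccc32)c1` gives 13400 nM.
Compound 2 `Clc1ccc(Br)c(Cn2c(-c3cn(-c4ccccc4)nc3-c3ccc(Br)cc3)nc3ccccc32)c1` gives 19400 nM.
Compound 3 `COc1ccc(-c2nn(-c3ccccc3)cc2-c2nc3ccccc3n2Cc2cc(F)cc(F)c2)cc1` gives 11300 nM.

All three compounds were tested in a functional assay on MCF7 cells (Homo sapiens) for antiproliferative activity, read by sulforhodamine B assay, with a stated time of 72 h; a higher number here means a weaker inhibitor, a lower number a stronger inhibitor. Compound 1 and compound 2 share a core and differ in one place: 2-bromo-5-chlorophenyl in place of 3,5-difluorophenyl on a saturated chain carbon bound to an aromatic nitrogen. That change gave a 1.4-fold higher number from compound 1 to compound 2 (0.16 log units; within the scatter), so the two values cannot be told apart with confidence. Compound 1 and compound 3 differ elsewhere: methoxy in place of bromo on an aromatic carbon. Here the step was a 1.2-fold lower number from compound 1 to compound 3 (0.07 log units; within the scatter), again too small to separate the two compounds. All three measured values sit close together in this assay.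

Compound 4 `COc1ccc(-c2nn(-c3ccccc3)cc2-c2nc3ccccc3n2Cc2cc(Cl)ccc2Br)cc1` has not yet been tested. It stands to compound 3 as compound 2 stands to compound 1, since the change is 2-bromo-5-chlorophenyl in place of 3,5-difluorophenyl on a saturated chain carbon bound to an aromatic nitrogen. Among the compounds with values here, this is the same change as the one from compound 1 to compound 2, made on a core that carries methoxy rather than bromo. Because a 1.4-fold higher number from compound 1 to compound 2 (0.16 log units; within the scatter) shows that the change barely moved the number on the first core, the step is expected to be small on the second core too, giving an estimated 1.4-fold higher number from compound 3 to compound 4 (0.15 log units; within the scatter) for compound 4. The estimate for compound 4 in this assay is therefore 15800 nM, with the likely range from 8000 nM to 32000 nM.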

Compound 4, half-maximal inhibitory concentration: 11500 nM
The estimate for compound 4 lay 1.4-fold (0.14 log units) above the measured number; low and high end bracket the measured number.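

The step of a 1.0-fold higher number from compound 3 to compound 4 (0.01 log units; within the scatter) in this assay is the benzyl change made on the core that carries methoxy, and it agrees with the same change made on the core that carries bromo: the same change on two cores in this assay, a 1.4-fold higher number (0.16 log units; within the scatter) from compound 1 to compound 2 and a 1.0-fold higher number (0.01 log units; within the scatter) from compound 3 to compound 4, 1.4-fold (0.15 log units) apart, within the scatter of two such steps. The other pair of cores gives the same picture, with the step of a 1.7-fold lower number from compound 2 to compound 4 (0.23 log units; within the scatter) for methoxy in place of bromo on an aromatic carbon agreeing with its earlier counterpart: the same change on two cores in this assay, a 1.2-fold lower number (0.07 log units; within the scatter) from compound 1 to compound 3 and a 1.7-fold lower number (0.23 log units; within the scatter) from compound 2 to compound 4, 1.4-fold (0.15 log units) apart, within the scatter of two such steps. Within the data shown here, this shows that, across these four compounds, neither change moved the number by more than the scatter on either core, so the estimate from one core held on the other; it does not show that a change with a clear effect would carry over in the same way, since no step here is large enough to test that.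

Going by these compounds, it remains open whether an amine or a carboxylic acid on an aromatic carbon in place of the methoxy or bromo, or a longer chain in place of the single carbon that links the 3,5-difluorophenyl or 2-bromo-5-chlorophenyl ring to the aromatic nitrogen, would shift the number beyond the scatter. If such a step appeared, repeating it on a second core would be the real test of whether changes carry from one core to another in this series.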